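Methylating Both Hydroxyls of Compound 3

The compounds below may be only part of what the source reports. "The series", "measured", "known", "first", "only" and "open" are said of these compounds alone.

Compound 3 `O=C(N/N=C/c1ccc(O)c(O)c1)c1cccnc1Nc1cccc(C(F)(F)F)c1` gives 50.8% in a functional assay on the whole organism (strain Wistar) for inhibition, with Rattus norvegicus as the target, read by paw edema, with a stated time of 1 h, at a dose of 10 mg/kg by the intraperitoneal route; a higher number here means more inhibition at the dose given (going by the name of the read-out), a lower number less inhibition. That is the second highest of three numbers: compound 1 `O=C(N/N=C/c1ccc(F)cc1)c1cccnc1Nc1cccc(C(F)(F)F)c1` gives 43.2%, and a number 7.6 percentage points higher from compound 1 to compound 3 (within the scatter); compound 2 `O=C(N/N=C/c1cccc(Cl)c1)c1cccnc1Nc1cccc(C(F)(F)F)c1` gives 76.7%, and a number 25.9 percentage points lower from compound 2 to compound 3 (beyond the scatter). Compound 4 `COc1ccc(/C=N/NC(=O)c2cccnc2Nc2cccc(C(F)(F)F)c2)cc1OC` differs from compound 3 in one place: 3,4-dimethoxyphenyl in place of 3,4-dihydroxyphenyl on a carbon with a double bond to nitrogen. Among the compounds with values here, no measured step covers an exchange of hydroxyl for methoxy; the steps seen so far only swap one aryl group for another, and a number 33.5 percentage points higher from compound 1 to compound 2 (beyond the scatter) shows such swaps can move the number a lot, while the step from compound 1 to compound 3 stayed within the scatter. Compound 4 is therefore expected to stay close to that value, with an estimated step of a number 1.2 percentage points higher from compound 3 to compound 4 (within the scatter). For compound 4 the expected value is 52%, between 35% and 70%.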

Compound 4, a percentage reported as inhibition, in the whole organism at one dose (the size of the read-out at that dose, not a potency): 70%
Beside the measured number, compound 4's estimate is 18 percentage points below it, within the range that was stated.
By their numbers in this assay, from the lowest: compounds 1 and 3 (each within the scatter of the next); then compounds 4 and 2 (each within the scatter of the next).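

Methylating both hydroxyls shows that this position responds to a change in the substituents alone, with the ring pattern kept: a number 19.2 percentage points higher from compound 3 to compound 4 (beyond the scatter) is the step in this assay. The 3,4-dimethoxyphenyl group also stands level with 3-chlorophenyl, with a number 6.7 percentage points lower from compound 2 to compound 4 (within the scatter) as the step, and clear of 4-fluorophenyl, with a number 26.8 percentage points higher from compound 1 to compound 4 (beyond the scatter) as the step. Nothing available explains why the methoxy groups differ from the hydroxyls. Going by these compounds, whether a single methoxy group would be enough remains open, as does whether a longer chain such as ethoxy or an amine at these ring sites would give a similar number.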